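The source may hold more compounds than are shown below. What is called first, only, known or untested is meant among the compounds shown, and "the series" means these compounds.

Among the compounds with values here, in a functional assay on HCT-116 cells (Homo sapiens) for inhibition, read by MTT assay, with a stated time of 48 h (a higher number here means a weaker inhibitor, a lower number a stronger inhibitor), compound 3 (`COc1cc(-c2nnc(SCC(=O)c3ccc(F)cc3)n2-c2ccc(N(C)C)cc2)cc(OC)c1OC`) gives 31100 nM as the only number. Compound 1 (`CCSc1nnc(-c2cc(OC)c(OC)c(OC)c2)n1-c1ccc(N(C)C)cc1`) gives > 60000 nM as a limit of the assay. Compound 2 (`COc1ccc(C(=O)CSc2nnc(-c3cc(OC)c(OC)c(OC)c3)n2-c2ccc(N(C)C)cc2)cc1`) gives > 60000 nM as a limit too.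

Compound 4 (`COc1cc(-c2nnc(SCC(=O)Nc3ccc(Cl)cc3)n2-c2ccc(N(C)C)cc2)cc(OC)c1OC`) differs from compound 3 thus: (4-chlorophenyl)amino in place of 4-fluorophenyl on a carbonyl carbon and (4-fluorophenyl)carbonyl becomes (4-chlorophenyl)carbamoyl. Two measured steps change the same chain: an at least 1.9-fold lower number from compound 1 to compound 3 (0.28 log units; that floor lies within the scatter) and an at least 1.9-fold lower number from compound 2 to compound 3 (0.28 log units; that floor lies within the scatter) have floors within the scatter. Neither introduces (4-chlorophenyl)carbamoyl, so neither gives a size or direction for this change. With compound 3 at 31100 nM as the anchor in this assay the expected step is a 1.0-fold lower number from compound 3 to compound 4 (0.02 log units; within the scatter) and nothing beyond the scatter is expected. Compound 4 is estimated at 30000 nM (12000 nM to 60000 nM).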

Compound 4, half-maximal inhibitory concentration: 39300 nM
For compound 4 the middle estimate is 1.3-fold (0.12 log units) below the measured one; the measured number falls inside the stated range.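

In this assay, replacing 4-fluorophenyl on the carbonyl carbon with (4-chlorophenyl)amino gives a 1.3-fold higher number from compound 3 to compound 4 (0.10 log units; within the scatter), so this chain position accepts a hydrogen-bond donor and a chlorine with no change beyond the scatter. Against the two compounds held at limits, the floors are an at least 1.5-fold lower number from compound 2 to compound 4 (0.18 log units; that floor lies within the scatter) and an at least 1.5-fold lower number from compound 1 to compound 4 (0.18 log units; that floor lies within the scatter), and neither shows a gain beyond the scatter. Not every compound in the series gives a number: the limit of > 60000 nM in this assay, at which 2 of the 4 values shown sit.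

The step from compound 3 to compound 4 changes the linking atoms and the halogen together, so their separate contributions stay unresolved. From the compounds shown here alone, whether an amine or a carboxylic acid on this chain would give a step beyond the scatter remains open.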